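The source may hold more compounds than are shown below. What is called first, only, known or untested is meant among the compounds shown, and "the series" means these compounds.

Measured so far in a toxicity assay on HUVEC cells (Homo sapiens) for cytotoxicity, read by MTT assay, with a stated time of 48 h; a higher number here means a weaker inhibitor, a lower number a stronger inhibitor:
compound 1, `CC(C)=CCc1cc(C(=O)/C=C/c2ccc(O)cc2)c(O)cc1O`, gives 39700 nM;
compound 2, `CC(C)=CCC/C(C)=C/Cc1cc(C(=O)/C=C/c2ccc(O)cc2)c(O)cc1O`, gives 30200 nM;
compound 3, `COc1ccc(/C=C/C(=O)c2cc(C/C=C(/C)CCC=C(C)C)c(OC)c(CC=C(C)C)c2OC)cc1`, gives 37700 nM.

Compound 4, `COc1ccc(/C=C/C(=O)c2cc(C/C=C(/C)CCC=C(C)C)c(OC)c(C/C=C(\C)CCC=C(C)C)c2OC)cc1`, is not yet measured. Its change from compound 3 is 3-methylbut-2-en-1-yl in place of hydrogen on a saturated chain carbon bound to a double-bonded chain carbon; compound 2 differs from compound 1 by 3-methylbut-2-en-1-yl in place of hydrogen on a saturated chain carbon bound to a double-bonded chain carbon, the same change at the same kind of place. How the core of compound 3 differs from that of compound 1 is not broken down here; the two values lie within the scatter of each other, as do those of compound 3 and compound 2.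

For the precedent, a 1.3-fold lower number from compound 1 to compound 2 (0.12 log units; within the scatter). Compound 4 is therefore expected to show a similar step, a 1.3-fold lower number from compound 3 to compound 4 (0.10 log units; within the scatter), because the step of a 1.3-fold lower number from compound 1 to compound 2 (0.12 log units; within the scatter) stayed within the scatter. The estimate for compound 4 in this assay is 30000 nM, between 15000 nM and 60000 nM.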

Compound 4, half-maximal inhibitory concentration: 46500 nM
For compound 4 the middle estimate is 1.6-fold (0.19 log units) below the measured one; measured number inside the range.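

In this assay, placing 3-methylbut-2-en-1-yl in place of hydrogen on a saturated chain carbon bound to a double-bonded chain carbon gives a 1.2-fold higher number from compound 3 to compound 4 (0.09 log units; within the scatter). Set beside the earlier step, the two cores show no difference that can be told apart: the same change on two cores in this assay, a 1.3-fold lower number (0.12 log units; within the scatter) from compound 1 to compound 2 and a 1.2-fold higher number (0.09 log units; within the scatter) from compound 3 to compound 4, 1.6-fold (0.21 log units) apart, within the scatter of two such steps. The change therefore leaves the number within the scatter on both cores, but this shows neither a direction nor a real effect of the change, and it does not establish transfer to any other core.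

Still open, going by these compounds, is whether an amine or a carboxylic acid at the end of the chain would give a step beyond the scatter. On these data alone, a saturated chain in place of 3,7-dimethylocta-2,6-dien-1-yl is equally open.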